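Aryl amide replaces branched alkyl at the amide nitrogen

The source may report more compounds than this note shows. Statements on the series, on what has been measured and on what is new or still open speak of the compounds shown alone.

Compound 1 `C=CC1=C(C(=O)NCCCCC)C(c2ccc(Cl)c(Cl)c2)OC1` and compound 2 `C=CC1=C(C(=O)NCC(C)C)C(c2ccc(Cl)c(Cl)c2)OC1` share one core and differ only in the group on the amide nitrogen. In a functional assay on SW480 cells (Homo sapiens) for cytotoxicity, read by MTT assay, with a stated time of 24 h (a lower number here means a stronger inhibitor, a higher number a weaker inhibitor), compound 1 gives 27500 nM. For compound 2 only a limit of this assay is known, > 100000 nM. The step of an at least 3.6-fold higher number from compound 1 to compound 2 (0.56 log units; beyond the scatter) is therefore bounded on one side alone, since one of the two values sits at the limit (the limit of > 100000 nM in this assay, at which 1 of the 2 values shown sits). Compound 2 thus stands at the weak edge of what this assay can report.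

Compound 3 `C=CC1=C(C(=O)Nc2ccccc2OC)C(c2ccc(Cl)c(Cl)c2)OC1` carries the change (2-methoxyphenyl in place of isobutyl on an amide-type nitrogen). Going by the values given here, no measured step involves an aromatic group on the amide nitrogen; the single step available, from the longer butyl chain to the branched isobutyl, shows a weakening, but it does not tell how an aromatic ring would behave. With the starting point itself at a limit, the direction from compound 2 to compound 3 cannot be fixed by the data. The author expects for compound 3 a value near 50000 nM, with a range from 10000 nM to 200000 nM, which is expected to mean a step of an at least 2.0-fold lower number from compound 2 to compound 3 (0.30 log units; that floor lies within the scatter) from compound 2, though a further limit result is considered quite possible.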

Compound 3, half-maximal inhibitory concentration: > 100000 nM
Compound 3 ended at the assay's limit (the forecaster's own chance of this, stated with the estimate: 45%); at least 2.0-fold (0.30 log units) between middle value and limit.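

In this assay, compound 3 extends the picture from alkyl groups to an aromatic group on the amide-type nitrogen, and the 2-methoxyphenyl group does not return a readable value. Compound 3 gives > 100000 nM, which is a limit of the assay and not a number. Replacing pentyl with 2-methoxyphenyl gives an at least 3.6-fold higher number from compound 1 to compound 3 (0.56 log units; beyond the scatter), so both replacements of the pentyl chain shown here, the isobutyl and the 2-methoxyphenyl group, lead to a weaker result, and the step between those two cannot be read, which leaves them unranked and compound 1 as the only compound with a measured number: the limit of > 100000 nM in this assay, at which 2 of the 3 values shown sit.

The compounds shown leave open whether any other group on this nitrogen would give a lower number than the pentyl chain of compound 1, for example a longer chain such as octyl, or a chain ending in an amine or a carboxylic acid. They also leave open how an unsubstituted phenyl or a benzyl group would read here, and whether a readable value can be obtained with any ring on this nitrogen at all.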